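Ethyl to methyl on compound 1

The compounds below may be only part of what the source reports. "The series", "measured", "known", "first", "only" and "open" are said of these compounds alone.

Measured so far in a functional assay on MV4-11 cells (Homo sapiens) for inhibition, read by resazurin assay, with a stated time of 72 h; on this read-out lower numbers stand for stronger inhibition of growth and higher numbers for weaker inhibition of growth
compound 1 `CCn1cc(-c2ccnc(Nc3ccc(OC)cc3OC)n2)c2ccccc21` gives 3590 nM
compound 2 `COc1ccc(Nc2nccc(-c3sc(SC(C)C)nc3C)n2)c(OC)c1` gives 5670 nM
compound 3 `COCCSc1nc(C)c(-c2ccnc(Nc3ccc(OC)cc3OC)n2)s1` gives 810 nM

Compound 1 lies within the scatter of compound 2, and compound 3 shows the lowest number. Going by the values given here, compound 4 `COc1ccc(Nc2nccc(-c3cn(C)c4ccccc34)n2)c(OC)c1` differs from compound 1 by hydrogen in place of methyl on a saturated chain carbon bound to an aromatic nitrogen as its one change: hydrogen in place of methyl on a saturated chain carbon bound to an aromatic nitrogen. Among the compounds with values here, the only measured step, a 7.0-fold lower number from compound 2 to compound 3 (0.85 log units; beyond the scatter), concerns a chain on a sulfur, so it bears only weakly here. Within the data shown here, no measured pair covers this place. The expected change is a 1.1-fold lower number from compound 1 to compound 4 (0.05 log units; within the scatter), which means none beyond the scatter. For compound 4 the estimated value is 3200 nM, with an expected range from 1300 nM to 7500 nM in this assay.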

Compound 4, concentration for 50% growth inhibition: 3410 nM
Estimate against measurement, compound 4: 1.1-fold (0.03 log units) below; the range from low to high includes it.
By their numbers in this assay, from the lowest: compound 3; then compounds 4, 1 and 2 (each within the scatter of the next).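

In this assay, ethyl to methyl at this place gives a 1.1-fold lower number from compound 1 to compound 4 (0.02 log units; within the scatter), the first step read here. Across this one-carbon change, hydrogen in place of methyl on a saturated chain carbon bound to an aromatic nitrogen, the number stays within the scatter, so removing this methyl leaves growth inhibition unchanged in this pair. No measured evidence bears on this result.

Only ethyl and methyl are shown here, so the effect of a longer chain such as butyl remains open. Also open, going by these compounds, is whether a chain ending in an amine or a carboxylic acid would change the number.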